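Nitro in place of cyano: working notes on compound 3

The source may hold more compounds than are shown below. What is called first, only, known or untested is meant among the compounds shown, and "the series" means these compounds.

Values measured in a functional assay on Jurkat cells (Homo sapiens) (a higher number here means a weaker inhibitor, a lower number a stronger inhibitor), so far:
- compound 1 `CC(C)[C@H](NC(=O)COc1cccc2ccccc12)C(=O)N[C@@H](CC(=O)O)C(=O)COC(=O)c1c(Cl)cccc1Cl` gives 10600 nM
- compound 2 `CC(C)[C@H](NC(=O)COc1cccc2ccccc12)C(=O)N[C@@H](CC(=O)O)C(=O)COc1ccc(C#N)cc1` gives > 100000 nM as a limit, not a number

Compound 2 stands at > 100000 nM in this assay as a limit, so it has no exact place on the scale. Compound 3 `CC(C)[C@H](NC(=O)COc1cccc2ccccc12)C(=O)N[C@@H](CC(=O)O)C(=O)COc1ccc([N+](=O)[O-])cc1` carries nitro in place of cyano on an aromatic carbon, para to a large group.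

Going by the values given here, the only measured step is an at least 9.4-fold higher number from compound 1 to compound 2 (0.97 log units; beyond the scatter) and it lies beyond the scatter. Among the compounds with values here, that step replaces the whole group on the oxygen, (2,6-dichlorophenyl)carbonyl giving way to 4-cyanophenyl, and no measured step changes the cyano group itself. It therefore gives no direct size for this swap. With compound 2 at a limit, no direction can be fixed, and no step beyond the scatter is expected in this assay here. The expected change is a number no higher from compound 2 to compound 3 (the limit leaves the size open) and it may appear only as a reading at the limit. In this assay for compound 3 the estimated value is 100000 nM with an expected range from 30000 nM to 300000 nM and a reading given only as a limit is quite likely.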

Compound 3, half-maximal inhibitory concentration: > 100000 nM
Compound 3 ended at the assay's limit; the forecaster's own chance of this, stated with the estimate: 75%; the middle value lies on the limit itself.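

The step from compound 2 to compound 3 cannot be read in this assay, because both compounds sit at the limit, so nothing can be said about the size or direction of the change from cyano to nitro: the limit of > 100000 nM in this assay, at which 2 of the 3 values shown sit. Putting 4-nitrophenyl in place of (2,6-dichlorophenyl)carbonyl on the oxygen gives an at least 9.4-fold higher number from compound 1 to compound 3 (0.97 log units; beyond the scatter), which matches the printed lower bound of the earlier change to 4-cyanophenyl, an at least 9.4-fold higher number from compound 1 to compound 2 (0.97 log units; beyond the scatter). With two different groups at this place on the aromatic ring both ending at the limit, the loss against compound 1 no longer rests on the cyano group alone.

From the compounds shown here alone, how far compound 2 and compound 3 lie past the limit, and whether they differ from each other, stays open. Also open, going by these compounds, is whether an amine or a methoxy group on this aromatic carbon would bring a reading back onto the scale, and whether the carbonyl or the two chlorines of the (2,6-dichlorophenyl)carbonyl group account for the measurable value of compound 1.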